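The source may hold more compounds than are shown below. What is called first, only, known or untested is meant among the compounds shown, and "the series" means these compounds.

Compound 1 `COc1ccc(S(=O)(=O)NCCN2CCC(CCC(=O)c3cc(Cl)c(N)cc3OC)CC2)cc1Br` is a sulfonamide whose aromatic ring carries a bromo and a methoxy group. In an assay on brain for displacement of a labelled ligand from 5-hydroxytryptamine receptor 4 (Cavia porcellus), with a stated time of 30 min, in the presence of a further agent that is not named here (a lower number here means a stronger inhibitor, a higher number a weaker inhibitor), compound 1 gives 24.3 nM, the highest of the three numbers measured here. Compound 2 `COc1ccc(S(=O)(=O)NCCN2CCC(CCC(=O)c3cc(Cl)c(N)cc3OC)CC2)cc1`, in which hydrogen takes the place of that bromo on an aromatic carbon, gives 12.3 nM in this assay, and the step of a 2.0-fold lower number from compound 1 to compound 2 (0.30 log units; within the scatter) stays within the scatter. Compound 3 `COc1ccc(S(=O)(=O)CCCN2CCC(CCC(=O)c3cc(Cl)c(N)cc3OC)CC2)cc1`, which joins the sulfonyl group to the rest of the molecule through a carbon chain rather than a nitrogen, gives 12.2 nM in this assay, a number that also lies within the scatter of the value of compound 1.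

Compound 4 `COc1cc(N)c(Cl)cc1C(=O)CCC1CCN(CCNS(=O)(=O)c2cc(Br)c(N)c(Br)c2)CC1` differs from compound 1 by 4-amino-3,5-dibromophenyl in place of 3-bromo-4-methoxyphenyl on a sulfonyl sulfur. Going by the values given here, only the step from compound 1 to compound 2 touches this part of the molecule, and it stayed within the scatter; no measured step brings an amino group or a second bromo onto this ring. The change is therefore expected to give a step of no more than the scatter, a 1.0-fold lower number from compound 1 to compound 4 (0.01 log units; within the scatter). Compound 4 is expected to give 24 nM in this assay, with a range from 8 nM to 75 nM.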

Compound 4, inhibition constant: 8.7 nM
For compound 4 the middle estimate is 2.8-fold (0.44 log units) above the measured one, and the stated range covers the measured number.
By their numbers in this assay, from the lowest: compounds 4, 3, 2 and 1 (each within the scatter of the next, the first and the last beyond it).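

In this assay the ring on the sulfonyl sulfur now shows a step beyond the scatter: 4-amino-3,5-dibromophenyl in place of 3-bromo-4-methoxyphenyl gives a 2.8-fold lower number from compound 1 to compound 4 (0.45 log units; beyond the scatter) and is modest in size. Against the simpler 4-methoxyphenyl ring, the same kind of replacement gives a 1.4-fold lower number from compound 2 to compound 4 (0.15 log units; within the scatter) and stays within the scatter, so the ring with an amino group and two bromo groups differs clearly from only one of the two rings it is compared with. No measurement here explains the size of either step.

Compound 4 brings in the amino group and the second bromo together, so the compounds shown do not tell which of them matters. Also open, going by these compounds, is how a plain 4-aminophenyl ring, or a nitrile or carboxylic acid on this ring, would behave.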